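A few compounds are considered here, and "the series" means these few. Any claim that something is new, unique, unknown or untested is made for them only; others in the source may bear on it.

Among the measured compounds shown here, compound 1 `COc1ccc(/C=C2\Cc3ccccc3/C(=C\c3ccc([N+](=O)[O-])cc3)C2=O)cc1` is the first measured compound. In a functional assay on HPLF cells (Homo sapiens) for cytotoxicity (a lower number here means that less compound is tolerated, a higher number that more compound is tolerated), compound 1 gives > 400000 nM, which is a limit of the assay and not a number. Compound 2 `COc1ccc(/C=C2\CCC/C(=C\c3ccc([N+](=O)[O-])cc3)C2=O)cc1OC` in this assay gives 95000 nM. Compound 3 `COc1ccc(/C=C2\Cc3ccccc3/C(=C\c3ccc([N+](=O)[O-])cc3)C2=O)cc1OC` in this assay gives > 400000 nM, again a limit of the assay rather than a number.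

The difference between the cores of compound 1 and compound 2 is not broken down here. From compound 1 to compound 3 the change is methoxy in place of hydrogen on an aromatic carbon, and the step it made in this assay is a step that the two limits leave unreadable from compound 1 to compound 3, unreadable because of the limit of > 400000 nM in this assay, at which 2 of the 3 values shown sit. Compound 4 `COc1cc(/C=C2\CCC/C(=C\c3ccc([N+](=O)[O-])cc3)C2=O)cc(OC)c1OC` is not yet measured. It arises from compound 2 by the same kind of change, (methoxy in place of hydrogen on an aromatic carbon), where the place is also meta to a methoxy group. For the measured compounds named here, as the only readable number belongs to compound 2, the step from compound 2 to compound 4 is expected to be a 1.3-fold higher number from compound 2 to compound 4 (0.10 log units; within the scatter). Compound 4 is therefore estimated at about 120000 nM, expected between 30000 nM and 400000 nM.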

Compound 4, half-maximal cytotoxic concentration: 378000 nM
The estimate for compound 4 lay 3.2-fold (0.50 log units) below the measured number; the range from low to high includes it.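

In this assay, methoxy in place of hydrogen on an aromatic carbon gives a 4.0-fold higher number from compound 2 to compound 4 (0.60 log units; beyond the scatter), so on the core of compound 2 this change goes with more compound being tolerated. As far as these compounds go, whether it carries over to the core of compound 1 stays unknown, because compound 1 and compound 3 both give a limit of the assay rather than a number, and the step between them cannot be read: the limit of > 400000 nM in this assay, at which 2 of the 4 values shown sit. One readable step on one core therefore shows no transfer between cores and gives no reason for the rise.

Still open, from the compounds shown here alone, is how other groups on that aromatic carbon would behave. An amine, a hydroxy group or a longer chain such as propoxy might move the number differently from methoxy.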